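Clearance Shift on Swapping an Alkyne for Benzothiophene

This account rests on a few compounds, and the source may have more. Where it says the series, first, only, none or still open, it means among the compounds named here.

Compound 1, `Nc1ccc(S(=O)(=O)N2CCN(c3ncc(C(O)(C(F)(F)F)C(F)(F)F)cc3C#CC3CC3)CC2)cn1`: < 14 mL.min-1.g-1
Compound 2, `COCC#Cc1cc(C(O)(C(F)(F)F)C(F)(F)F)cnc1N1CCN(S(=O)(=O)c2ccc(N)nc2)CC1`: 15 mL.min-1.g-1
Compound 3, `Cc1ccc(-c2cc(C(O)(C(F)(F)F)C(F)(F)F)cnc2N2CCN(S(=O)(=O)c3ccc(N)nc3)CC2)cn1`: 43 mL.min-1.g-1

In an ADME assay (liver) for metabolic stability, with Liver microsome (Homo sapiens) as the target, using microsomes and NADPH, with a stated time of 30 min, tested at 1 uM (on this read-out higher numbers stand for fast clearance and lower numbers for slow clearance), compound 2 gives 15 mL.min-1.g-1, the lower of the two full numbers in this series; the nearest number belongs to compound 3, which gives 43 mL.min-1.g-1 in this assay. Compound 1 is reported only as a limit of this assay, (the limit of < 14 mL.min-1.g-1 in this assay, at which 1 of the 3 values shown sits), and not as a number. The change from compound 2 to compound 4, `Nc1ccc(S(=O)(=O)N2CCN(c3ncc(C(O)(C(F)(F)F)C(F)(F)F)cc3-c3ccc4sccc4c3)CC2)cn1`, is 1-benzothiophen-5-yl in place of 3-methoxyprop-1-yn-1-yl on an aromatic carbon. The step that bears most directly on it is a 2.9-fold higher number from compound 2 to compound 3 (0.46 log units; beyond the scatter), where a 3-methoxyprop-1-yn-1-yl group was likewise replaced by a ring system on the same aromatic carbon. The companion step an at least 3.0-fold higher number from compound 1 to compound 3 (0.48 log units; beyond the scatter) points the same way, while an at least 1.0-fold higher number from compound 1 to compound 2 (0.02 log units; that floor lies within the scatter) shows that the two triple-bonded substituents sit within the scatter of each other. On this basis a rise in clearance beyond the scatter is expected for compound 4, estimated as a 4.0-fold higher number from compound 2 to compound 4 (0.60 log units; beyond the scatter). Compound 4 is therefore expected to give about 60 mL.min-1.g-1 in this assay, with a plausible range from 30 mL.min-1.g-1 to 120 mL.min-1.g-1.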

Compound 4, intrinsic clearance in microsomes: 48 mL.min-1.g-1
Compound 4: middle estimate off by 1.3-fold (0.10 log units), on the high side; the measured number falls inside the stated range.
By their numbers in this assay, from the lowest: compound 2; then compounds 3 and 4 (each within the scatter of the next). At a limit, below all of these: compound 1.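

In this assay, 1-benzothiophen-5-yl on this aromatic carbon gives a 3.2-fold higher number from compound 2 to compound 4 (0.51 log units; beyond the scatter) and an at least 3.4-fold higher number from compound 1 to compound 4 (0.53 log units; beyond the scatter), so a second compound with an aromatic ring system at this position, after compound 3, reads on the high side of the two triple-bonded substituents. The two ring systems themselves cannot be told apart, with a 1.1-fold higher number from compound 3 to compound 4 (0.05 log units; within the scatter), so a fused pair of aromatic rings carrying sulfur moves this read-out no further than the single 6-methylpyridin-3-yl ring does. Compound 1 remains a limit of the assay and not a number: the limit of < 14 mL.min-1.g-1 in this assay, at which 1 of the 4 values shown sits.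

Open, as far as these compounds go, is whether a cyclohexyl or a plain phenyl group on this carbon would read with compound 3 and compound 4 or with compound 2, which would separate the effect of having an aromatic ring here from that of losing the triple bond. From the compounds shown here alone, the true size of the gap between compound 1 and the other three also stays open, compound 1 being known only as a limit.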